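The compounds below may be only part of what the source reports. "The series", "measured", "known", "first", "only" and "open" are said of these compounds alone.

Measured so far:
- compound 1 `CCOc1ccc(Br)cc1C(C)NC(=O)N(C)S(=O)(=O)c1ccc(C)cc1` at 28600 nM
- compound 2 `CCOc1ccc(Br)cc1C(C)NC(=O)N(C)S(=O)(=O)c1ccc(Cl)cc1` at 55700 nM

In a functional assay on thoracic aorta (Rattus norvegicus, strain Wistar), with a stated time of 15 min (a lower number here means that less compound is needed, a higher number that more compound is needed for the effect), compound 2 at 55700 nM sits within the scatter of compound 1 and is not separated from it. Compound 3 `CC(C)Oc1ccc(Br)cc1C(C)NC(=O)N(C)S(=O)(=O)c1ccc(Cl)cc1` differs from compound 2 by methyl in place of hydrogen on a saturated chain carbon bound to an oxygen on an aromatic ring and a saturated chain carbon and so takes ethoxy to isopropoxy. For the measured compounds named here, the only measured step of a 1.9-fold higher number from compound 1 to compound 2 (0.29 log units; within the scatter) lies within the scatter and concerns chloro in place of methyl on an aromatic carbon, so no measured step tests this chain. No step beyond the scatter is therefore expected in this assay and the estimated 1.2-fold lower number from compound 2 to compound 3 (0.09 log units; within the scatter) reflects that. For compound 3 the estimated value is 45000 nM with an expected range of 18000 nM to 110000 nM on this reading.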

Compound 3, half-maximal effective concentration: 43200 nM
For compound 3 the middle estimate is 1.0-fold (0.02 log units) above the measured one; the range from low to high includes it.
By their numbers in this assay, from the lowest: compounds 1, 3 and 2 (each within the scatter of the next).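

For the compounds shown here, this is the first measured step at the ether chain: in this assay, ethoxy to isopropoxy gives a 1.3-fold lower number from compound 2 to compound 3 (0.11 log units; within the scatter), so compound 3 is not separated from compound 2. An added methyl on this saturated chain carbon therefore leaves the read-out within the scatter, as chloro in place of methyl did on the aromatic carbon. No measurement at hand bears on why this is so.

On these data alone, whether a longer chain such as butoxy, or an amine or carboxylic acid on this chain, would give a step beyond the scatter stays open. No change shown so far is tied to a difference beyond the scatter.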